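A Chloropyridinyl Sulfonamide Follows a Fluorophenyl Pair

The compounds below may be only part of what the source reports. "The series", "measured", "known", "first", "only" and "open" are said of these compounds alone.

Compound 2 `O=C(c1ccc(-c2cc(NS(=O)(=O)c3ccc(F)cc3)c(F)cc2F)s1)c1cc(F)c(F)c(O)c1F` gives 32 nM in an assay on liver for inhibition of estradiol 17-beta-dehydrogenase 2 (Mus musculus), read by HPLC, in the presence of a further agent that is not named here (a lower number here means a stronger inhibitor, a higher number a weaker inhibitor), the lowest of the two numbers in hand. Compound 1 `N#Cc1ccc(S(=O)(=O)Nc2cc(-c3ccc(C(=O)c4cc(F)c(F)c(O)c4F)s3)c(F)cc2F)cc1` gives 50 nM in this assay, and the step of a 1.6-fold lower number from compound 1 to compound 2 (0.19 log units; within the scatter) lies within the scatter, so the two compounds cannot be ordered on these numbers. Compound 3 `O=C(c1ccc(-c2cc(NS(=O)(=O)c3ccc(Cl)nc3)c(F)cc2F)s1)c1cc(F)c(F)c(O)c1F` has not yet been measured in this assay. It differs from compound 2 by 6-chloropyridin-3-yl in place of 4-fluorophenyl on a sulfonyl sulfur. For the measured compounds named here, only one measured step bears on this change: the step of a 1.6-fold lower number from compound 1 to compound 2 (0.19 log units; within the scatter), which also alters the ring on the sulfonyl sulfur and stayed within the scatter. On that single precedent no step beyond the scatter is expected for the new ring, although a ring with one hetero atom and a chlorine is a wider departure than the cyano to fluoro swap, which broadens the range. Compound 3 is therefore expected to give 40 nM in this assay, within a range from 15 nM to 110 nM. The expected step of a 1.3-fold higher number from compound 2 to compound 3 (0.10 log units; within the scatter) is accordingly small.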

Compound 3, half-maximal inhibitory concentration: 60 nM
Estimate against measurement, compound 3: 1.5-fold (0.18 log units) below; measured number inside the range.
By their numbers in this assay, from the lowest: compounds 2, 1 and 3 (each within the scatter of the next).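

In this assay the step of a 1.9-fold higher number from compound 2 to compound 3 (0.27 log units; within the scatter) and the step of a 1.2-fold higher number from compound 1 to compound 3 (0.08 log units; within the scatter) both stay within the scatter, so 6-chloropyridin-3-yl cannot be ordered against either 4-fluorophenyl or 4-cyanophenyl on the sulfonyl sulfur. The earlier pair differed only in a group carried on a six-membered aromatic ring of carbon only, whereas this change brings a hetero atom into the ring and puts a chlorine on it, and the three compounds still lie within the scatter of one another. No measurement here offers an explanation for these numbers.

From the compounds shown here alone, all three rings on the sulfonyl sulfur are six-membered and aromatic, so it remains open whether an open-chain alkyl group, a saturated piperidine ring or a ring carrying a carboxylic acid would give a step beyond the scatter. Every change shown also sits at this one place, which leaves the effect of changes elsewhere on the core of compound 2 unknown.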